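Aryl for Methyl on the Oxadiazole of an Indole Series

The source may report more compounds than this note shows. Statements on the series, on what has been measured and on what is new or still open speak of the compounds shown alone.

In a functional assay on Jurkat cells (Homo sapiens) for antiproliferative activity, read by WST assay, with a stated time of 72 h (a higher number here means a weaker inhibitor, a lower number a stronger inhibitor), compound 1 `Cc1noc(-c2cc3ccccc3[nH]2)n1` reaches only a limit of the assay, > 50000 nM. Compound 2 `Cc1noc(-c2cc3cc(F)ccc3[nH]2)n1` gives 22900 nM and compound 3 `Cc1noc(-c2cc3cc(Cl)ccc3[nH]2)n1` gives 21600 nM, so compound 3 and compound 2 sit within the scatter of each other. The steps of an at least 2.1-fold lower number from compound 1 to compound 2 (0.33 log units; beyond the scatter) and an at least 2.3-fold lower number from compound 1 to compound 3 (0.36 log units; beyond the scatter) were both at least modest, whereas a 1.1-fold lower number from compound 2 to compound 3 (0.03 log units; within the scatter) stayed within the scatter. Compound 4 `Clc1ccc(-c2noc(-c3cc4cc(Cl)ccc4[nH]3)n2)cc1` differs from compound 3 by 4-chlorophenyl in place of methyl on an aromatic carbon. For the measured compounds named here, none of the measured steps touches this part of the shared core, so no step size can be read across from them, and the expectation rests on the change itself. Compound 4 is therefore estimated at 8000 nM, with a range from 1500 nM to 40000 nM. That estimate corresponds to an expected step of a 2.7-fold lower number from compound 3 to compound 4 (0.43 log units; beyond the scatter), a cautious guess toward a lower number.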

Compound 4, half-maximal inhibitory concentration: > 50000 nM
Compound 4: no number, only a limit (the forecaster's own chance of this, stated with the estimate: 15%); middle value at least 6.2-fold (0.79 log units) away from the limit.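

For the compounds shown here, at this position, on an aromatic carbon between two ring nitrogen atoms, the earlier compounds showed no change at all, and the first step read here, an at least 2.3-fold higher number from compound 3 to compound 4 (0.36 log units; beyond the scatter), runs opposite to the fluoro and chloro steps elsewhere on the shared core. Compound 4 gives only a limit, > 50000 nM. The size of this step is therefore a bound and not a measure: the limit of > 50000 nM in this assay, at which 2 of the 4 values shown sit.

From the compounds shown here alone, it remains open whether ethyl, unsubstituted phenyl or a phenyl carrying an amine or a carboxylic acid would keep, raise or lower the number at this position.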